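The source may report more compounds than this note shows. Statements on the series, on what has been measured and on what is new or still open speak of the compounds shown alone.

Measured compounds:
- compound 1, `Clc1ccccc1NCc1nc2ccc(Br)cc2[nH]1`, gives 22.2% in a functional assay on the whole organism (strain albino) for inhibition, with Rattus norvegicus as the target, read by paw edema, with a stated time of 180 min, at a dose of 100 mg/kg by the oral route; a higher number here means more inhibition at the dose given (going by the name of the read-out), a lower number less inhibition
- compound 2, `Brc1ccc(NCc2nc3ccc(Br)cc3[nH]2)cc1`, gives 16.6% in this assay
- compound 3, `COc1ccc(NCc2nc3ccccc3[nH]2)cc1`, gives 33.3% in this assay

All three share the same core, a benzimidazole-like fused ring bearing a methylene that links to an aniline nitrogen; they differ only in the groups on the outer rings. Compound 3, the only one carrying a methoxy on the aniline ring and no bromine on the core, stands highest of the three numbers. Its nearest neighbour is compound 1, whose value lies lower by more than the usual scatter, and the furthest is compound 2, whose value lies lower still, also beyond the scatter.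

Compound 4, `c1ccc(NCc2nc3ccccc3[nH]2)cc1`, has not yet been measured. It differs from compound 3 in one place: hydrogen in place of methoxy on an aromatic carbon. Compound 4 is thus the bare parent of this small set, with no substituent on either ring.

Among the compounds with values here, no pair of measured compounds differs in just one place, so there is no measured step to lean on. Within the data shown here, since the unsubstituted aniline ring of compound 4 has no direct precedent here, the expected change is small, and the step from compound 3 to compound 4 is estimated at a number 8.3 percentage points lower from compound 3 to compound 4 (within the scatter), a modest fall that may well sit within the scatter. Compound 4 is therefore expected to give about 25%, within a range from 12% to 38%.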

Compound 4, a percentage reported as inhibition, in the whole organism at one dose (the size of the read-out at that dose, not a potency): 38.8%
Compound 4: the middle estimate sits 13.8 percentage points below what was measured; measured number outside the range, above it.
By their numbers in this assay, from the lowest: compounds 2 and 1 (each within the scatter of the next); then compounds 3 and 4 (each within the scatter of the next).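

Within the data shown here, replacing methoxy with hydrogen on an aromatic carbon, para to a large group, gives the first comparison here between compounds that differ in only one place: in this assay, the result is a number 5.5 percentage points higher from compound 3 to compound 4 (within the scatter). The methoxy group, with its 2 heavy atoms and 1 hydrogen-bond acceptor, can therefore be removed from this position without a difference that stands out from ordinary repeat-to-repeat variation, so this pair gives no sign that the group is needed for the read-out. No measurement shown explains why the two compounds read alike.

The compounds shown leave open whether a different group at this position, such as an amine, a carboxylic acid or a longer chain, would move the number beyond the scatter. They also leave open whether the same swap would give a similar result on a core carrying bromine, like the core of compound 1, as this single pair speaks only for the unbrominated core of compound 3 and compound 4.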